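The source may hold more compounds than are shown below. What is called first, only, known or untested is meant among the compounds shown, and "the series" means these compounds.

Working notes on the series

All three measured compounds share one core and differ only in the benzyl piece bound to sulfur. In a functional assay on SW 1116 cells (Homo sapiens) for antiproliferative activity, read by MTT assay, with a stated time of 48 h (on this read-out lower numbers stand for stronger inhibition and higher numbers for weaker inhibition), compound 2 `Brc1ccccc1CSc1nnc(-c2ccc3c(c2)OCCO3)o1` gives 14100 nM. Compound 1 `O=[N+]([O-])c1ccccc1CSc1nnc(-c2ccc3c(c2)OCCO3)o1` carries nitro in place of bromo on an aromatic carbon and in this assay gives 20800 nM, a step of a 1.5-fold higher number from compound 2 to compound 1 (0.17 log units; within the scatter). Compound 3 `Brc1ccc(CSc2nnc(-c3ccc4c(c3)OCCO4)o2)cc1` carries 4-bromophenyl in place of 2-bromophenyl on a saturated chain carbon bound to a sulfur relative to compound 2; in this assay compound 3 gives 24500 nM, a step of a 1.7-fold higher number from compound 2 to compound 3 (0.24 log units; within the scatter). All three numbers lie within the scatter of one another, so no order among them is claimed.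

Compound 4 `O=[N+]([O-])c1ccc(CSc2nnc(-c3ccc4c(c3)OCCO4)o2)cc1` is not yet measured. It relates to compound 3 by nitro in place of bromo on an aromatic carbon. This is the same kind of change as that from compound 2 to compound 1, though there the place was ortho to a large group and here it is para to a large group. For compound 4 a step of a 1.2-fold higher number from compound 3 to compound 4 (0.09 log units; within the scatter) is expected in this assay, because a 1.5-fold higher number from compound 2 to compound 1 (0.17 log units; within the scatter) was within the scatter. Compound 4 is therefore estimated at 30000 nM, roughly between 12000 nM and 75000 nM.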

Compound 4, half-maximal inhibitory concentration: 14600 nM
Estimate against measurement, compound 4: 2.1-fold (0.31 log units) above; the measured number falls inside the stated range.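

In this assay, nitro in place of bromo on an aromatic carbon, para to a large group, gives a 1.7-fold lower number from compound 3 to compound 4 (0.22 log units; within the scatter). The two steps for this change point in opposite directions, but the gap between them does not exceed what two such steps can scatter: the same change on two cores in this assay, a 1.5-fold higher number (0.17 log units; within the scatter) from compound 2 to compound 1 and a 1.7-fold lower number (0.22 log units; within the scatter) from compound 3 to compound 4, 2.5-fold (0.39 log units) apart, within the scatter of two such steps. This shows that on these two pairs the change carries over as a step too small to read, and it does not show a true reversal of direction from one core to the other, or that the step would stay this small on any further core.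

The compounds shown carry only bromo or nitro on the benzyl ring, so all four numbers say nothing about how an amine, a carboxylic acid or a methoxy group would behave there. They also leave open whether a longer chain on the sulfur, in place of the single saturated carbon, would give a step beyond the scatter.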